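Anilide variation on the shared core in KB cells

The source may hold more compounds than are shown below. What is called first, only, known or untested is meant among the compounds shown, and "the series" means these compounds.

Compound 1, `Cc1cccc(NC(=O)COc2ccc(/C=C3\SC(=O)NC3=O)cc2)n1`, gives 75000 nM in a functional assay on KB cells (Homo sapiens) for inhibition; on this read-out higher numbers stand for weaker inhibition of growth and lower numbers for stronger inhibition of growth.
Compound 2, `O=C(COc1ccc(/C=C2\SC(=O)NC2=O)cc1)Nc1cccc([N+](=O)[O-])c1`, reaches only the limit of > 100000 nM in this assay.
Compound 3, `O=C(COc1ccc(/C=C2\SC(=O)NC2=O)cc1)Nc1ccccc1`, likewise reaches only the limit of > 100000 nM in this assay.

Compound 3 thus stands at the limit of the assay, and of the three values shown, two sit there (the limit of > 100000 nM in this assay, at which 2 of the 3 values shown sit). Among the measured compounds shown here, the step from the one full number reads an at least 1.3-fold higher number from compound 1 to compound 3 (0.12 log units; that floor lies within the scatter), and the parallel exchange reads an at least 1.3-fold higher number from compound 1 to compound 2 (0.12 log units; that floor lies within the scatter); both floors lie within the scatter. Between the two limits the step that the two limits leave unreadable from compound 2 to compound 3 cannot be read.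

Compound 4, `Cc1cc(Br)ccc1NC(=O)COc1ccc(/C=C2\SC(=O)NC2=O)cc1`, is not yet measured. It differs from compound 3 in one place: 4-bromo-2-methylphenyl in place of phenyl on an amide-type nitrogen. For the measured compounds named here, both exchanges on the amide-type nitrogen that have been measured led to the limit, and no measured step shows the bromine or the methyl on this phenyl. The author therefore expects no readable step beyond the scatter, and estimates a number no higher from compound 3 to compound 4 (the limit leaves the size open). In this assay compound 4 is expected at about 100000 nM, with a range from 40000 nM to 300000 nM, most probably again reported only as a limit.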

Compound 4, concentration for 50% growth inhibition: > 100000 nM
Compound 4 gave a limit, no number (the forecaster's own chance of this, stated with the estimate: 70%); the middle value sits exactly at the limit.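

Compound 4 shows that 4-bromo-2-methylphenyl on the amide-type nitrogen, carrying both a bromine and a methyl on the phenyl, brings no full number in this assay, and so joins phenyl and 3-nitrophenyl at the limit: the limit of > 100000 nM in this assay, at which 3 of the 4 values shown sit. The steps among the three compounds at this limit cannot be read. Among the compounds shown here, the only readable new step is an at least 1.3-fold higher number from compound 1 to compound 4 (0.12 log units; that floor lies within the scatter), so this comparison shows no difference beyond the scatter either.

The compounds shown leave open how compound 2, compound 3 and compound 4 stand relative to one another past their shared limit, and whether the bromine or the methyl alone on this phenyl would give a full number in this assay. They also leave open what a carboxylic acid or an amine on this phenyl would give in this assay.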